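A few compounds are considered here, and "the series" means these few. Any claim that something is new, unique, unknown or untested is made for them only; others in the source may bear on it.

Measured so far in a toxicity assay on MT4 cells (Homo sapiens) for cytotoxicity, read by MTT assay, with a stated time of 5 days; on this read-out higher numbers stand for lower toxicity in this test and lower numbers for higher toxicity in this test:
- compound 1 `Cc1ccc(-c2cc(C)c(Nc3ccnc(Nc4ccc(C#N)cc4)n3)c(C)c2)s1`: 28000 nM
- compound 2 `COc1ncc(-c2cc(C)c(Nc3ccnc(Nc4ccc(C#N)cc4)n3)c(C)c2)cn1`: 4800 nM

Of these two, compound 2 has the lower number, 4800 nM, so it is the more toxic in this test. Compound 3 `Cc1cc(-c2cnc(C(F)(F)F)nc2)cc(C)c1Nc1ccnc(Nc2ccc(C#N)cc2)n1` has trifluoromethyl in place of methoxy on an aromatic carbon, between two ring nitrogen atoms: trifluoromethyl in place of methoxy on an aromatic carbon. Going by the values given here, only one measured step bears on this: a 5.8-fold lower number from compound 1 to compound 2 (0.77 log units; beyond the scatter). That modest step exchanged 5-methylthiophen-2-yl for 2-methoxypyrimidin-5-yl, a whole group, whereas the new change swaps only the methoxy. Among the compounds with values here, no measured compound carries trifluoromethyl, so the direction is uncertain. A smaller step than that one is expected, probably none beyond the scatter, with a slight lean towards a higher number. The expected step is a 1.5-fold higher number from compound 2 to compound 3 (0.16 log units; within the scatter). For compound 3 the estimated value is 7000 nM, with an expected range from 2500 nM to 20000 nM.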

Compound 3, half-maximal cytotoxic concentration: 4900 nM
For compound 3 the middle estimate is 1.4-fold (0.15 log units) above the measured one, within the range that was stated.
By their numbers in this assay, from the lowest: compounds 2 and 3 (each within the scatter of the next); then compound 1.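

In this assay, trifluoromethyl in place of methoxy on this carbon, between two ring nitrogen atoms, gives a 1.0-fold higher number from compound 2 to compound 3 (0.01 log units; within the scatter) and so leaves no readable difference, although the two groups differ in heavy atoms and hydrogen-bond acceptors. The change of the whole group gives a 5.7-fold lower number from compound 1 to compound 3 (0.76 log units; beyond the scatter) and stays close in size to a 5.8-fold lower number from compound 1 to compound 2 (0.77 log units; beyond the scatter) in both of the compared compounds, so here the gap from compound 1 does not depend on which of these two groups the pyrimidin-5-yl ring carries. Nothing available gives a cause for this result.

From the compounds shown here alone, whether an amine or a carboxylic acid on this same carbon would also stay within the scatter remains open. Also open, going by these compounds, is whether the gap from compound 1 follows from its thiophene ring or from the methyl group on that ring.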